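Chain length and cytotoxicity across three measured analogues

The compounds below may be only part of what the source reports. "The series", "measured", "known", "first", "only" and "open" are said of these compounds alone.

Measured so far:
compound 1 `CCCCCCCC(=O)Nc1nnc(S[C@@H]2O[C@H](CO)[C@H](O)[C@H](O)[C@H]2O)s1` — 50800 nM
compound 2 `CCCCCC(=O)Nc1nnc(S[C@@H]2O[C@H](CO)[C@H](O)[C@H](O)[C@H]2O)s1` — 45600 nM
compound 3 `CCCCCCCCCCCCCCCC(=O)Nc1nnc(S[C@@H]2O[C@H](CO)[C@H](O)[C@H](O)[C@H]2O)s1` — 14200 nM

All three values come from a functional assay on HeLa cells (Homo sapiens) for cytotoxicity, read by MTT assay, with a stated time of 24 h; a lower number here means a stronger inhibitor, a higher number a weaker inhibitor. The shortening hydrogen in place of ethyl on a saturated chain carbon, five bonds along the chain from a carbonyl carbon gave a 1.1-fold lower number from compound 1 to compound 2 (0.05 log units; within the scatter), so compound 1 and compound 2 are not told apart here. Lengthening the chain gave a 3.6-fold lower number from compound 1 to compound 3 (0.55 log units; beyond the scatter) and a 3.2-fold lower number from compound 2 to compound 3 (0.51 log units; beyond the scatter), and compound 3 stands with the lowest number of the three, beyond the scatter from both.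

Compound 4 `CCCCCCCCCCCCCC(=O)Nc1nnc(S[C@@H]2O[C@H](CO)[C@H](O)[C@H](O)[C@H]2O)s1` is not yet measured. It differs from compound 3 by hydrogen in place of ethyl on a saturated chain carbon, ten or more bonds along the chain from a carbonyl carbon. The same kind of change, (hydrogen in place of ethyl on a saturated chain carbon, five bonds along the chain from a carbonyl carbon), was made from compound 1 to compound 2 and gave a 1.1-fold lower number from compound 1 to compound 2 (0.05 log units; within the scatter). The places along the chain from the carbonyl carbon are not the same. The core of compound 3 differs from that of compound 1 by octyl in place of hydrogen on a saturated chain carbon, seven bonds along the chain from a carbonyl carbon.

Compound 4 sits between compound 3 and compound 1 in chain length. Because a 1.1-fold lower number from compound 1 to compound 2 (0.05 log units; within the scatter) was within the scatter, a small step is expected for compound 4, likely toward a somewhat higher number, since a 3.6-fold lower number from compound 1 to compound 3 (0.55 log units; beyond the scatter) ran the other way. The expected step is a 1.3-fold higher number from compound 3 to compound 4 (0.10 log units; within the scatter). Compound 4 is estimated at 18000 nM, with a range from 9000 nM to 36000 nM.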

Compound 4, half-maximal inhibitory concentration: 31000 nM
Compound 4: middle estimate off by 1.7-fold (0.24 log units), on the low side; the range from low to high includes it.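

In this assay the change from ethyl to hydrogen gives a 2.2-fold higher number from compound 3 to compound 4 (0.34 log units; beyond the scatter) and, set beside the earlier case at a different place along the chain, shows no difference between the two cores: the same change on two cores in this assay, a 1.1-fold lower number (0.05 log units; within the scatter) from compound 1 to compound 2 and a 2.2-fold higher number (0.34 log units; beyond the scatter) from compound 3 to compound 4, 2.4-fold (0.39 log units) apart, within the scatter of two such steps. The change that adds a chain to hydrogen gives a 1.5-fold lower number from compound 2 to compound 4 (0.17 log units; within the scatter) and also stays level with its earlier counterpart: the same change on two cores in this assay, a 3.6-fold lower number (0.55 log units; beyond the scatter) from compound 1 to compound 3 and a 1.5-fold lower number (0.17 log units; within the scatter) from compound 2 to compound 4, 2.4-fold (0.39 log units) apart, within the scatter of two such steps. Together with a 1.6-fold lower number from compound 1 to compound 4 (0.21 log units; within the scatter) this leaves compound 3 alone beyond the scatter from the other three compounds, while compound 1, compound 2 and compound 4 are not told apart; the comparisons do not contradict carrying either change from one core to another, but they do not establish a fixed step, since each rests on a single pair of steps, the places along the chain differ, and one step of each pair lies within the scatter and the other beyond it.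

Still open, from the compounds shown here alone, is whether the lower number of compound 3 persists with a longer chain, or is confined to this one chain length. The shared core also leaves open how a carboxylic acid or an amine at the far end of the chain would read against these values.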